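The source may report more compounds than this note shows. Statements on the series, on what has been measured and on what is new or still open speak of the compounds shown alone.

Of the compounds shown here, two have so far been measured in an assay on isolated protein for inhibition of Gonadotropin-releasing hormone receptor (Rattus norvegicus); a lower number here means a stronger inhibitor, a higher number a weaker inhibitor. Compound 1 `O=S(=O)(NCc1ccc(F)cc1)c1ccc2c(c1)nc(C1CC1)n2Cc1ccccc1` gives 1600 nM in this assay. Compound 2 `CC(C)(C)NC(=O)CCCc1nc2cc(S(=O)(=O)NCc3ccc(F)cc3)ccc2n1Cc1ccccc1` carries a 3-((tert-butyl)carbamoyl)propyl chain on an aromatic carbon where compound 1 has a cyclopropyl, and in this assay compound 2 gives 230 nM. That single exchange brought a 7.0-fold lower number from compound 1 to compound 2 (0.84 log units; beyond the scatter). Compound 2 thus holds the lowest of the two numbers shown, and the only other measured compound, compound 1, stands clearly higher.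

Compound 3 `CC(C)(C)NC(=O)NCCCc1nc2cc(S(=O)(=O)NCc3ccc(F)cc3)ccc2n1Cc1ccccc1` differs from compound 2 by ((tert-butyl)carbamoyl)amino in place of (tert-butyl)carbamoyl on a saturated chain carbon, three bonds along the chain from an aromatic carbon. For the measured compounds named here, the one measured step, between compound 1 and compound 2, concerns swapping a small ring for the whole chain, not the form of the group at the end of that chain, so no measured step bears directly on this change. With nothing pointing in either direction, the expected outcome in this assay is no change at the digits printed from compound 2 to compound 3 (within the scatter), that is, no step beyond the scatter. Compound 3 is therefore estimated at 230 nM, with a range from 70 nM to 800 nM.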

Compound 3, half-maximal inhibitory concentration: 83 nM
Compound 3: the middle estimate sits 2.8-fold (0.44 log units) above what was measured; the range from low to high includes it.
By their numbers in this assay, from the lowest: compound 3; then compound 2; then compound 1.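

The form of the group at the end of the chain matters in this assay, not just the presence of a chain: ((tert-butyl)carbamoyl)amino in place of (tert-butyl)carbamoyl gives a 2.8-fold lower number from compound 2 to compound 3 (0.44 log units; beyond the scatter), a change at a saturated chain carbon, three bonds along the chain from an aromatic carbon. Measured against the cyclopropyl, the full 3-(((tert-butyl)carbamoyl)amino)propyl chain gives a 19-fold lower number from compound 1 to compound 3 (1.29 log units; beyond the scatter), a step classed as large, whereas the earlier chain exchange gave a 7.0-fold lower number from compound 1 to compound 2 (0.84 log units; beyond the scatter) and was classed as modest. The entering group has one more nitrogen than the group it replaces, with 2 hydrogen-bond donors instead of 1, but nothing available explains why this exchange lowers the number.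

Every chain shown ends in tert-butyl, so it remains open whether that group is needed or how a methyl group at the same end would compare. Also open, going by these compounds, is how this assay would read for a shorter or longer chain with the same end group, or for a chain ending in an amine or a carboxylic acid.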